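Butyl amide in place of ethoxyphenyl amide on the benzyl core

The source may report more compounds than this note shows. Statements on the series, on what has been measured and on what is new or still open speak of the compounds shown alone.

In an ADME assay on SW480 cells (Homo sapiens) for cytotoxicity, read by MTT assay, with a stated time of 72 h (on this read-out higher numbers stand for weaker inhibition and lower numbers for stronger inhibition), compound 3 `CCOc1ccc(NC(=O)c2cccc(/C=C3\CC(=O)N(Cc4ccccc4)C3=O)c2)cc1` gives 73200 nM. Compound 1 `CCc1cccc(NC(=O)c2cccc(/C=C3\CC(=O)N(Cc4ccccc4)C3=O)c2)c1` gives 91500 nM, and the step of a 1.3-fold lower number from compound 1 to compound 3 (0.10 log units; within the scatter) leaves these two numbers within the scatter of each other. Compound 2 `CCCCCN1C(=O)C/C(=C\c2cccc(C(=O)NCCCC)c2)C1=O` gives > 100000 nM, a limit of the assay rather than a number (the limit of > 100000 nM in this assay, at which 1 of the 3 values shown sits). Compound 4 `CCCCNC(=O)c1cccc(/C=C2\CC(=O)N(Cc3ccccc3)C2=O)c1` differs from compound 3 by butyl in place of 4-ethoxyphenyl on an amide-type nitrogen. For the measured compounds named here, no measured step covers this change directly: the step from compound 1 to compound 3 exchanges one aryl group for another and stays within the scatter, while compound 2 carries the same butylamino group and gives only a limit. The step from compound 3 to compound 4 is therefore expected as a 1.8-fold higher number from compound 3 to compound 4 (0.25 log units; within the scatter), toward weaker inhibition and possibly past the limit. Compound 4 is estimated at 130000 nM, with a range from 55000 nM to 300000 nM.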

Compound 4, half-maximal inhibitory concentration: > 100000 nM
Compound 4 gave a limit, no number (the forecaster's own chance of this, stated with the estimate: 60%); the middle value lies beyond the limit too.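

In this assay, butyl on the amide-type nitrogen gives no number, unlike the aryl groups of compound 1 and compound 3, and only floors can be read: an at least 1.3-fold higher number from compound 3 to compound 4 (0.13 log units; that floor lies within the scatter) and an at least 1.0-fold higher number from compound 1 to compound 4 (0.03 log units; that floor lies within the scatter). The step between compound 2 and compound 4 cannot be read, as both values are limits. Both compounds carrying butylamino now sit at the same limit: the limit of > 100000 nM in this assay, at which 2 of the 4 values shown sit.

Going by these compounds, both floors lie within the scatter, so the true size of the change stays open. Also open, on these data alone, is whether an amine or a carboxylic acid on the butyl chain, or a longer chain, would return a number.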